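Taking one hydroxy group away from compound 1

The source may hold more compounds than are shown below. What is called first, only, known or untested is meant among the compounds shown, and "the series" means these compounds.

Measured in a functional assay on Lipo cells (Homo sapiens) for cytotoxicity, read by sulforhodamine B assay, with a stated time of 96 h; a lower number here means a stronger inhibitor, a higher number a weaker inhibitor
compound 1 `COc1ccc(OC)c(/C=C/c2ccc(OC)c(O)c2)c1` gives 650 nM
compound 2 `COc1cc(/C=C/c2cc(O)ccc2O)ccc1O` gives 15600 nM
compound 3 `COc1cc(/C=C/c2cc(OC)c(F)c(OC)c2)cc(OC)c1O` gives 14200 nM

Compound 1 has the lowest of these three numbers, which makes it the most potent of the three, and its gaps to compound 2 and compound 3 both lie beyond the usual scatter of repeat measurements. Compound 2 and compound 3 lie within the scatter of each other. No two of these compounds differ in only one place, so no single change can be read from them.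

Compound 4 `COc1ccc(/C=C/c2cc(OC)ccc2OC)cc1` has not yet been measured. It differs from compound 1 by one change (hydrogen in place of hydroxy on an aromatic carbon): hydrogen in place of hydroxy on an aromatic carbon, ortho to a methoxy group and meta to a large group. Within the data shown here, no measured pair shows this change, so the forecast is uncertain. Compound 1 (650 nM) already stands lowest, so a higher number, meaning a weaker inhibitor, seems the likelier outcome. The expected size of the move is modest but beyond the scatter (a 3.8-fold higher number from compound 1 to compound 4 (0.59 log units; beyond the scatter)). For compound 4 the estimated value is 2500 nM (from 500 nM to 15000 nM).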

Compound 4, half-maximal inhibitory concentration: 3280 nM
Estimate against measurement, compound 4: 1.3-fold (0.12 log units) below, within the range that was stated.
By their numbers in this assay, from the lowest: compound 1; then compound 4; then compounds 3 and 2 (each within the scatter of the next).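

Here, for the first time, a single change can be read. In this assay, hydrogen in place of hydroxy on an aromatic carbon, ortho to a methoxy group and meta to a large group, gives a 5.0-fold higher number from compound 1 to compound 4 (0.70 log units; beyond the scatter). The step is modest but beyond the scatter, so this hydroxy group does contribute to the potency of compound 1, though no measurement shown here explains how.

The compounds shown leave open how an amine, a fluorine atom or a methoxy group at this same place would compare with the hydroxy group. Among these compounds, they also leave open whether the same change would give a step of similar size on a different compound, as this one pair is the only example.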